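The source may hold more compounds than are shown below. What is called first, only, known or untested is meant among the compounds shown, and "the series" means these compounds.

Measured values in a functional assay on MCF7 cells (Homo sapiens) for cytotoxicity, read by MTT assay, with a stated time of 24 h (a lower number here means a stronger inhibitor, a higher number a weaker inhibitor), so far
Compound 1 `C/C(=N\NC(=O)/C(C#N)=C/c1ccc(O)cc1)c1c(O)c2ccc(O)cc2oc1=O` gives 7320 nM
Compound 2 `COc1cc(/C=C(\C#N)C(=O)N/N=C(\C)c2c(O)c3ccc(O)cc3oc2=O)ccc1O` gives 13700 nM

These two results cannot be told apart. The comparison gives a 1.9-fold higher number from compound 1 to compound 2 (0.27 log units; within the scatter) and shows methoxy in place of hydrogen on an aromatic carbon, so compound 2 stands level with compound 1 within the normal spread of repeat measurements.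

Compound 3 `C/C(=N\NC(=O)/C(C#N)=C/c1ccc(N(C)C)cc1)c1c(O)c2ccc(O)cc2oc1=O` has not yet been measured. It carries 4-(dimethylamino)phenyl in place of 4-hydroxy-3-methoxyphenyl on a double-bonded chain carbon bound to a double-bonded chain carbon. Among the measured compounds shown here, the single measured step bears on this change only loosely, since it also falls within the group that leaves. For the measured compounds named here, no measured compound carries the entering group, so the data offer one small precedent and nothing direct. On these data alone, on that thin basis, no shift beyond the scatter is expected in this assay and the direction stays open. The expected outcome is a 1.4-fold lower number from compound 2 to compound 3 (0.14 log units; within the scatter) in round terms. For compound 3 the estimated value is 10000 nM with an expected range from 3500 nM to 30000 nM as a deliberately wide guess.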

Compound 3, half-maximal inhibitory concentration: 3420 nM
Compound 3: the middle estimate sits 2.9-fold (0.47 log units) above what was measured; measured number outside the range, below it.
By their numbers in this assay, from the lowest: compound 3; then compounds 1 and 2 (each within the scatter of the next).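

In this assay, 4-(dimethylamino)phenyl in place of 4-hydroxy-3-methoxyphenyl on a double-bonded chain carbon bound to a double-bonded chain carbon gives a 4.0-fold lower number from compound 2 to compound 3 (0.60 log units; beyond the scatter), so changing this aryl group can shift the number beyond the scatter, which the earlier methoxy step did not show. The narrower change, dimethylamino in place of hydroxy on an aromatic carbon, gives a 2.1-fold lower number from compound 1 to compound 3 (0.33 log units; beyond the scatter), which is also beyond the scatter and leaves compound 3 with the lowest number of the three, although both steps are modest. Nothing available explains why this exchange lowers the number.

The compounds shown leave open whether the shift needs the whole dimethylamino group or would also appear with a plain amino group, a diethylamino group or a morpholine ring at the same place. They also leave open how much of the shift depends on the shared core, and whether compounds with a lower number in this assay would act as selectively on these cells as on healthy ones.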